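Swapping the Amide for a Trifluoromethyl-Bearing Sulfur Group

A few compounds are considered here, and "the series" means these few. Any claim that something is new, unique, unknown or untested is made for them only; others in the source may bear on it.

Compound 1 `CC#C[C@H]1CN(S(=O)(=O)c2ccc(N)nc2)CCN1c1ccc(C(=O)NC)cc1` carries a methylcarbamoyl group on its shared core. In an ADME assay (liver) for metabolic stability, with Liver microsome (Rattus norvegicus) as the target, using microsomes and NADPH, with a stated time of 30 min (a higher number here means faster removal of the compound, a lower number slower removal), compound 1 gives 41 mL.min-1.g-1, the highest of the three numbers, although both other compounds sit within the usual scatter of it. Compound 2 `CC#C[C@H]1CN(S(=O)(=O)c2ccc(N)nc2)CCN1c1ccc(S(=N)(=O)C2CC2)cc1` gives 23 mL.min-1.g-1, and compound 3 `CC#C[C@H]1CN(S(=O)(=O)c2ccc(N)nc2)CCN1c1ccc(S(N)(=O)=O)cc1` gives 30 mL.min-1.g-1. The steps of a 1.8-fold lower number from compound 1 to compound 2 (0.25 log units; within the scatter) and a 1.4-fold lower number from compound 1 to compound 3 (0.14 log units; within the scatter) both stay within the scatter. Compound 4 `CC#C[C@H]1CN(S(=O)(=O)c2ccc(N)nc2)CCN1c1ccc(S(=O)(=NC)C(F)(F)F)cc1` has not yet been measured; the change from compound 1 is a group of 8 heavy atoms (2 carbon, 1 nitrogen, 1 oxygen, 3 fluorine, 1 sulfur; no ring) in place of a group of 4 heavy atoms (2 carbon, 1 nitrogen, 1 oxygen; no ring), on an aromatic carbon. Both earlier exchanges at the same place left the number essentially unchanged, so no shift beyond the scatter is expected, at most a mild drop of about a 1.4-fold lower number from compound 1 to compound 4 (0.14 log units; within the scatter). Compound 4 is therefore estimated at 30 mL.min-1.g-1, expected to fall between 15 mL.min-1.g-1 and 60 mL.min-1.g-1.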

Compound 4, intrinsic clearance in microsomes: 257 mL.min-1.g-1
For compound 4 the middle estimate is 8.6-fold (0.93 log units) below the measured one; measured number outside the range, above it.
By their numbers in this assay, from the lowest: compounds 2, 3 and 1 (each within the scatter of the next); then compound 4.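

In this assay this position proves far from indifferent to its group: a 6.3-fold higher number from compound 1 to compound 4 (0.80 log units; beyond the scatter) and an 8.6-fold higher number from compound 3 to compound 4 (0.93 log units; beyond the scatter) and an 11-fold higher number from compound 2 to compound 4 (1.05 log units; beyond the scatter) all lie beyond the scatter. Sulfur alone does not go with the rise, since compound 2 and compound 3 also carry sulfur here and stay within the scatter of compound 1. Going by these compounds alone, of the four groups, only the one in compound 4 holds fluorine.

Still open, from the compounds shown here alone, is whether a plain methylsulfonyl group, or the same sulfur group with methyl in place of trifluoromethyl, would keep the number low. No measurement shown explains the rise.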